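Cyano for chloro at the far aryl ring

The source may report more compounds than this note shows. Statements on the series, on what has been measured and on what is new or still open speak of the compounds shown alone.

Compound 1 `Oc1ccccc1CNc1ccccc1` is reported as "not active" (no number reported) in a functional assay on Jurkat cells (Homo sapiens) for activation, with a stated time of 24 h (a higher number here means that more compound is needed for the effect, a lower number that less compound is needed), with no number given. Compound 2 `Oc1ccccc1CNc1ccc(-c2ccc(Cl)cc2)cc1` gives 2390 nM in this assay. Compound 3 `Oc1ccccc1CNc1ccc(-c2ccccc2Cl)cc1` is also reported as "not active" (no number reported) in this assay and so stands without a single number; one further entry in the series, compound 1, likewise carries no number, leaving compound 2 as the only numbered point. Compound 4 `N#Cc1ccccc1-c1ccc(NCc2ccccc2O)cc1` differs from compound 3 by cyano in place of chloro on an aromatic carbon. Going by the values given here, no step between measured compounds covers this change, so no size or direction can be read from the data, and the inactive compound 3 offers no anchor. Compound 4 is expected near 6000 nM, with a range from 1500 nM to 25000 nM in this assay, and a report of no activity is the more likely outcome.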

Compound 4, half-maximal effective concentration: "not active" (no number reported)
The entry for compound 4 holds no number, and the estimate cannot be compared.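

Compound 3 and compound 4 both stand without a number in this assay, so no step can be read between them. No evidence bears on this result.
The compounds shown leave open what cyano in place of chloro does in a compound with a numbered value.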